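The compounds below may be only part of what the source reports. "The series", "measured", "known", "first", "only" and "open" are said of these compounds alone.

Compound 1, `O=C(c1cc(Cl)ccc1-c1ncccn1)N1CC2(CC2)C[C@H]1CNc1cc(C(F)(F)F)ccn1`: 8.1 in a functional assay on CHO cells for antagonist activity at Orexin/Hypocretin receptor type 1 (Homo sapiens), read by FLIPR and calcium flux; a lower number here means a less potent compound, a higher number a more potent compound, by a factor of ten per unit of this negative logarithm.
Compound 2, `Cc1cnn(-c2ccc(C)nc2C(=O)N2CC3(CC3)C[C@H]2CNc2ccc(C(F)(F)F)cn2)c1`: 8.9 in this assay.
Compound 3, `O=C(c1nc(C(F)(F)F)ccc1-c1ncccn1)N1CC2(CC2)C[C@H]1CNc1ccc(C(F)(F)F)cn1`: 6.7 in this assay.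

Compound 2 stands highest of the three numbers. Compound 1 lies nearest, below it by a gap beyond the scatter; compound 3 lies furthest, also below it and well beyond the scatter. Compound 4, `Cc1ccc(OCc2ccccc2)c(C(=O)N2CC3(CC3)C[C@H]2CNc2ccc(C(F)(F)F)cn2)n1`, is not yet measured. Against compound 2 the change is benzyloxy in place of 4-methyl-1H-pyrazol-1-yl on an aromatic carbon. For the measured compounds named here, no step between measured compounds mirrors a benzyloxy in place of 4-methyl-1H-pyrazol-1-yl, so the direction rests on expectation alone; a moderate drop in this assay, beyond the scatter, is expected rather than a gain. Compound 4 is estimated at 7.8, within 7 to 8.6. The expected step is a number 1.10 log units lower from compound 2 to compound 4 (beyond the scatter).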

Compound 4, negative logarithm of the antagonist equilibrium constant: 8.6
Beside the measured number, compound 4's estimate is 0.80 log units below it; low and high end bracket the measured number.
By their numbers in this assay, from the lowest: compound 3; then compound 1; then compounds 4 and 2 (each within the scatter of the next).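

In this assay, benzyloxy in place of 4-methyl-1H-pyrazol-1-yl gives a number 0.30 log units lower from compound 2 to compound 4 (within the scatter) on this aromatic carbon, ortho to a large group. For this pair, the position accepts a six-membered aromatic ring of carbon only, so the number does not depend on the five-membered aromatic ring with 2 hetero atoms. Nothing available explains why the two groups read alike.

Open, on these data alone, is whether a much smaller group on this carbon, such as methoxy or an amine, would hold the number. Also open, as far as these compounds go, is whether a phenyl ring without the oxygen and methylene link would do the same.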